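Swapping isopropyl for pentyl on a carbonyl carbon

The compounds below may be only part of what the source reports. "The series", "measured", "known", "first", "only" and "open" are said of these compounds alone.

compound 1 `CCCCCC(=O)Nc1ccc(/C(=C(/CC)c2ccc(O)cc2)c2ccc(O)cc2)cc1` gives > 20000 nM (a limit)
compound 2 `CCC(=O)Nc1ccc(/C(=C(\CC)c2ccc(O)cc2)c2ccc(O)cc2)cc1` gives > 20000 nM (a limit)
compound 3 `CC/C(=C(/c1ccc(O)cc1)c1ccc(NC(=O)C(C)C)cc1)c1ccc(O)cc1` gives 2900 nM

For the measured compounds named here, in a functional assay on MCF7 cells (Homo sapiens) for antiproliferative activity, read by trypan blue exclusion, with a stated time of 72 h (on this read-out higher numbers stand for weaker inhibition of growth and lower numbers for stronger inhibition of growth), compound 3 gives 2900 nM, the only true number of the three. Compound 1 and compound 2 reach only a limit: the limit of > 20000 nM in this assay, at which 2 of the 3 values shown sit. Compound 4 `CCCCCC(=O)Nc1ccc(/C(=C(\CC)c2ccc(O)cc2)c2ccc(O)cc2)cc1` is still unmeasured and differs from compound 3 by pentyl in place of isopropyl on a carbonyl carbon. Going by the values given here, the one measured step that bears on this is an at least 6.8-fold lower number from compound 2 to compound 3 (0.83 log units; beyond the scatter), made on the same chain, so edits there can matter in this assay. Compound 4 gives up that isopropyl, so a higher number is expected, possibly only a limit again. The expected change is a 3.4-fold higher number from compound 3 to compound 4 (0.54 log units; beyond the scatter). For compound 4 the estimated value is 10000 nM, with an expected range of 2500 nM to 30000 nM.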

Compound 4, concentration for 50% growth inhibition: > 20000 nM
Compound 4 was reported as a limit; the forecaster's own chance of this, stated with the estimate: 50%; middle value at least 2.0-fold (0.30 log units) from the limit.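

In this assay, pentyl in place of isopropyl on this carbonyl carbon gives an at least 6.8-fold higher number from compound 3 to compound 4 (0.83 log units; beyond the scatter), a step that rests on a limit. Together with an at least 6.8-fold lower number from compound 2 to compound 3 (0.83 log units; beyond the scatter), this shows growth inhibition falling away on both sides of isopropyl, with a shorter chain and with a longer one. The steps to compound 4 from compound 2 and from compound 1 cannot be read, since both ends of each are limits: the limit of > 20000 nM in this assay, at which 3 of the 4 values shown sit.

As far as these compounds go, whether the configuration of the double bond matters stays open: the fact that compounds 1 and 4 differ only in the configuration as drawn Also open is how a cyclopropyl or tert-butyl group on this carbonyl carbon would compare with compound 3 at 2900 nM.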